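A few compounds are considered here, and "the series" means these few. Any claim that something is new, unique, unknown or untested is made for them only; others in the source may bear on it.

Measured in a functional assay on HepG2 cells (Homo sapiens) for inhibition, read by MTT assay, with a stated time of 3 days; on this read-out higher numbers stand for weaker inhibition and lower numbers for stronger inhibition:
- Compound 1 `CC[C@H](C)[C@H](NCC(=O)NNC(=O)COc1ccc(-c2nc3ccccc3s2)cc1OC)C(=O)O`: 3540 nM
- Compound 2 `CCOC(=O)CN(C)CC(=O)NNC(=O)COc1ccc(-c2nc3ccccc3s2)cc1OC`: 3180 nM
- Compound 3 `CCOC(=O)[C@H](CS)NCC(=O)NNC(=O)COc1ccc(-c2nc3ccccc3s2)cc1OC`: 3760 nM

Compound 3 stands level with the other two. The steps reaching it are small: a 1.1-fold higher number from compound 1 to compound 3 (0.03 log units; within the scatter), and a 1.2-fold higher number from compound 2 to compound 3 (0.07 log units; within the scatter).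

Compound 4 `CCOC(=O)[C@H](CS)N(CC(=O)NNC(=O)COc1ccc(-c2nc3ccccc3s2)cc1OC)C(C)=O` has acetyl in place of hydrogen on an amine nitrogen. For the measured compounds named here, no measured compound carries acetyl there, so the evidence is indirect. The nearest comparison is compound 2, with methyl on that nitrogen, although its other substituent differs too. The steps involving it are also small: a 1.1-fold lower number from compound 1 to compound 2 (0.05 log units; within the scatter), and a 1.2-fold higher number from compound 2 to compound 3 (0.07 log units; within the scatter).

No shift beyond the scatter is therefore expected, and the estimated step is a 1.1-fold lower number from compound 3 to compound 4 (0.03 log units; within the scatter). For compound 4 the estimate is 3500 nM, with an expected range of 1700 nM to 7000 nM.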

Compound 4, half-maximal inhibitory concentration: 3010 nM
Beside the measured number, compound 4's estimate is 1.2-fold (0.07 log units) above it; the measured number falls inside the stated range.
By their numbers in this assay, from the lowest: compounds 4, 2, 1 and 3 (each within the scatter of the next).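

In this assay, the hydrogen on this amine nitrogen gives way to acetyl with only a 1.2-fold lower number from compound 3 to compound 4 (0.10 log units; within the scatter), so this nitrogen accepts a hydrogen-to-acetyl swap without leaving the scatter. Compound 4 also stays level with the other two compounds, showing a 1.1-fold lower number from compound 2 to compound 4 (0.02 log units; within the scatter) and a 1.2-fold lower number from compound 1 to compound 4 (0.07 log units; within the scatter) in the comparisons that change the wider side chain. No measurement here explains this flat result. On these data alone, whether a benzoyl group or a longer acyl chain on this nitrogen would shift the number remains open.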